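Thiophene to furan swap on two nucleoside cores

The source may report more compounds than this note shows. Statements on the series, on what has been measured and on what is new or still open speak of the compounds shown alone.

Three nucleosides were tested in a functional assay on HeLa S3 cells (Homo sapiens) for antiproliferative activity, read by XTT assay, with a stated time of 72 h (a lower number here means a stronger inhibitor, a higher number a weaker inhibitor), and none gave a number. Compound 2 `Cc1ncnc2c1c(-c1cccs1)cn2[C@@H]1O[C@H](CO)[C@@H](O)[C@H]1O` reached only the limit > 15000 nM there. Compound 1 `Cc1ncnc2c1c(-c1ccoc1)cn2[C@@H]1O[C@H](CO)[C@@H](O)[C@H]1O`, which carries furan-3-yl in place of thiophen-2-yl on an aromatic carbon, likewise reached only the limit > 20000 nM in this assay. The resulting step that the two limits leave unreadable from compound 2 to compound 1 is therefore not readable, since both ends of it are limits the limit of > 15000 nM in this assay, at which 1 of the 3 values shown sits (the limit of > 20000 nM in this assay, at which 2 of the 3 values shown sit). Compound 3 `Nc1nc(N)c2c(-c3cccs3)cn([C@@H]3O[C@H](CO)[C@@H](O)[C@H]3O)c2n1` has a different core; the difference between the two cores is not broken down here. In this assay compound 3 also stopped at the limit > 20000 nM.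

Compound 4 `Nc1nc(N)c2c(-c3ccoc3)cn([C@@H]3O[C@H](CO)[C@@H](O)[C@H]3O)c2n1` arises from compound 3 by the same change, furan-3-yl in place of thiophen-2-yl on an aromatic carbon, the place being described in identical words for both pairs. Since the measured step from compound 2 to compound 1 could not be sized, and compound 3 itself sits at the limit > 20000 nM, compound 4 is expected to show at most a step that the limit leaves unreadable from compound 3 to compound 4 and most probably another limit. The estimate for compound 4 in this assay is 30000 nM, between 15000 nM and 100000 nM.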

Compound 4, half-maximal inhibitory concentration: > 20000 nM
Compound 4 ended at the assay's limit (the forecaster's own chance of this, stated with the estimate: 85%); the middle value lies beyond the limit too.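

In this assay compound 4 gave > 20000 nM which is a limit of the assay and not a number. Among the compounds shown here, compound 3 also stopped at a limit, so no step from compound 3 to compound 4 can be read. The compounds shown leave open whether furan-3-yl in place of thiophen-2-yl changes antiproliferative activity on either core.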